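Swapping the aryl ring on a dichlorophenyl-bearing core

The compounds below may be only part of what the source reports. "The series", "measured", "known", "first", "only" and "open" are said of these compounds alone.

Compound 1 `O=C1/C(=C\c2c(Cl)cccc2Cl)c2ccccc2N1c1c(Cl)cccc1Cl` in a functional assay on L132 cells (Homo sapiens) for cytotoxicity, read by MTT assay, with a stated time of 72 h (on this read-out lower numbers stand for an effect already at smaller amounts and higher numbers for an effect only at larger amounts of compound), reaches only the limit of > 100 ug/mL.
Compound 2 `CN(C)c1ccc(/C=C2\C(=O)N(c3c(Cl)cccc3Cl)c3ccccc32)cc1` likewise reaches only the limit of > 100 ug/mL.
Compound 3 `O=C1/C(=C\c2cccc(Br)c2)c2ccccc2N1c1c(Cl)cccc1Cl` gives 19 ug/mL.

Going by the values given here, compound 3 is thus the only member of the set with an actual number; the other two sit at the limit of > 100 ug/mL in this assay, at which 2 of the 3 values shown sit. The step that the two limits leave unreadable from compound 1 to compound 2 says nothing about size. Both steps that end at compound 3 point the same way: an at least 5.2-fold lower number from compound 1 to compound 3 (0.72 log units; beyond the scatter) and an at least 5.2-fold lower number from compound 2 to compound 3 (0.72 log units; beyond the scatter), so the 3-bromophenyl group goes with the only measurable effect seen so far.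

Compound 4 `O=C1/C(=C\c2ccccc2Cl)c2ccccc2N1c1c(Cl)cccc1Cl` differs from compound 3 in exactly that place: 2-chlorophenyl in place of 3-bromophenyl on a double-bonded chain carbon bound to a double-bonded ring carbon. A halogen stays on the ring, but now it is a single chlorine, and the only other chlorine-bearing ring at this position, the 2,6-dichlorophenyl of compound 1, gave a limit rather than a number. The relevant steps are therefore mixed in their message, and a moderate rise in the concentration needed seems the most likely outcome, with a real chance that the assay again reports only a limit. Compound 4 is expected to give about 40 ug/mL, within a range from 12 ug/mL to 100 ug/mL. The expected step is a 2.1-fold higher number from compound 3 to compound 4 (0.32 log units; beyond the scatter).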

Compound 4, concentration for half-maximal effect: > 100 ug/mL
Compound 4: a limit, no number (the forecaster's own chance of this, stated with the estimate: 35%); middle value at least 2.5-fold (0.39 log units) from the limit.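

The change from 3-bromophenyl to 2-chlorophenyl on the double-bonded chain carbon moves the read-out clearly (an at least 5.2-fold higher number from compound 3 to compound 4 (0.72 log units; beyond the scatter)), and compound 4 ends at a limit of this assay, not at a number. Keeping one halogen on this ring is therefore not enough to keep a measurable effect, which compound 1, with two chlorines on the ring, could not show. The steps linking compound 4 to compound 1 and compound 2 cannot be read, since both ends are limits, and compound 3 now stands alone against the other three compounds: the limit of > 100 ug/mL in this assay, at which 3 of the 4 values shown sit.

This change swaps bromine for chlorine and also moves the halogen on the ring, so the compounds shown cannot say which of the two matters, and a 3-chlorophenyl or 2-bromophenyl group would be needed to pull them apart. Also open, from the compounds shown here alone, is how a plain phenyl ring, or a ring carrying a carboxylic acid or an amine other than the dimethylamino group of compound 2, would behave at this position.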